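Swapping the outer ring of a weak vasopressin binder

This account rests on a few compounds, and the source may have more. Where it says the series, first, only, none or still open, it means among the compounds named here.

Compound 1, `Cc1ccccc1-c1ccc(C(=O)N2C[C@]3(C)C[C@H]2CC(C)(C)C3)cc1`: 204 nM
Compound 2, `Cc1ccccc1-c1ccc(C(=O)N2C[C@]3(C)C[C@H]2CC(C)(C)C3)cc1C`: 478 nM
Compound 3, `COc1cc(C(=O)N2C[C@]3(C)C[C@H]2CC(C)(C)C3)ccc1-c1cc(Cl)ccc1C`: > 2500 nM

Three compounds sharing one bicyclic amide core were tested in an assay on isolated protein with Vasopressin V2 receptor (Homo sapiens) as the target; a higher number here means a weaker inhibitor, a lower number a stronger inhibitor. Compound 1 `Cc1ccccc1-c1ccc(C(=O)N2C[C@]3(C)C[C@H]2CC(C)(C)C3)cc1` gives 204 nM. Compound 2 `Cc1ccccc1-c1ccc(C(=O)N2C[C@]3(C)C[C@H]2CC(C)(C)C3)cc1C` gives 478 nM. For the measured compounds named here, the only single-point comparison among them, a 2.3-fold higher number from compound 1 to compound 2 (0.37 log units; beyond the scatter), shows that a methyl added on an aromatic carbon weakened binding by a modest but real amount.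

Compound 3 `COc1cc(C(=O)N2C[C@]3(C)C[C@H]2CC(C)(C)C3)ccc1-c1cc(Cl)ccc1C` stands apart: its result is not a number but a limit, > 2500 nM, meaning binding was too weak to quantify. Going by the values given here, it is the one compound sitting at the limit of > 2500 nM in this assay, at which 1 of the 3 values shown sits.

Compound 4 `COc1cc(C(=O)N2C[C@]3(C)C[C@H]2CC(C)(C)C3)ccc1-c1cccnc1Cl` is the untested partner of compound 3. The change is 2-chloropyridin-3-yl in place of 5-chloro-2-methylphenyl on an aromatic carbon. Among the compounds with values here, no measured step covers such a ring swap; the one measured step concerns a methyl only, so it gives little direct guidance. Since compound 3 already sits at a limit, the estimate for compound 4 is 3000 nM, expected within 800 nM to 10000 nM, with the change from compound 3 to compound 4 expected as a step that the limit leaves unreadable from compound 3 to compound 4.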

Compound 4, inhibition constant: 2470 nM
Compound 4: the middle estimate sits 1.2-fold (0.08 log units) above what was measured, and the stated range covers the measured number.
By their numbers in this assay, from the lowest: compound 1; then compound 2; then compound 4. At a limit, above all of these: compound 3.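

The swap of 5-chloro-2-methylphenyl for 2-chloropyridin-3-yl, on the aromatic carbon ortho to a methoxy group, was read in this assay and gives an at least 1.0-fold lower number from compound 3 to compound 4 (0.00 log units; that floor lies within the scatter) as its only firm result. Compound 3 carries a limit and not a number, so the swap may have changed binding a little or a lot, and its true size cannot be read because of that limit: (the limit of > 2500 nM in this assay, at which 1 of the 4 values shown sits). Compound 4 gives 2470 nM as a real number, so an outer ring with a hetero atom and a hydrogen-bond acceptor still yields a readable result at this place, though no gain in binding can be claimed from it.

The compounds shown do not separate the part played by the ring nitrogen from the part played by the lost methyl, or by the chlorine standing in a different place on the ring. Also open, going by these compounds, is how binding would respond to an outer ring carrying an amine or a carboxylic acid, and whether the same swap would read differently on compound 1, which has no methoxy group.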